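A few compounds are considered here, and "the series" means these few. Any claim that something is new, unique, unknown or untested is made for them only; others in the source may bear on it.

In a functional assay on ZR-75-1 cells (Homo sapiens) for inhibition, read by MTT assay, with a stated time of 24 h (on this read-out lower numbers stand for stronger inhibition of growth and higher numbers for weaker inhibition of growth), compound 1 (`N[C@@H](CC(=O)OC[C@H]1O[C@@H](n2cc(F)c(=O)[nH]c2=O)C[C@@H]1O)C(=O)O`) gives 3900000 nM and compound 2 (`CC(C)[C@H](N)C(=O)OC[C@H]1O[C@@H](n2cc(F)c(=O)[nH]c2=O)C[C@@H]1O`) gives 2500000 nM, so compound 2 stands within the scatter of compound 1. Compound 3 (`N[C@@H](CCC(=O)OC[C@H]1O[C@@H](n2cc(F)c(=O)[nH]c2=O)C[C@@H]1O)C(=O)O`) carries 3-amino-3-carboxypropyl in place of 1-amino-2-methylpropyl on a carbonyl carbon. For the measured compounds named here, the only measured step bearing on this, a 1.6-fold lower number from compound 1 to compound 2 (0.19 log units; within the scatter), is an exchange on the same carbonyl carbon and stays within the scatter, so no step beyond the scatter is expected in this assay. The expected step is a 1.2-fold higher number from compound 2 to compound 3 (0.08 log units; within the scatter). For compound 3 the estimate is 3000000 nM, with an expected range of 1300000 nM to 7000000 nM.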

Compound 3, concentration for 50% growth inhibition: 1700000 nM
Compound 3: the middle estimate sits 1.8-fold (0.25 log units) above what was measured; measured number inside the range.
By their numbers in this assay, from the lowest: compounds 3, 2 and 1 (each within the scatter of the next, the first and the last beyond it).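

Across the acidic side chains, a 2.3-fold lower number from compound 1 to compound 3 (0.36 log units; beyond the scatter) in this assay, the first step in the series beyond the scatter, though a modest one, with 2-amino-2-carboxyethyl replaced by the longer 3-amino-3-carboxypropyl. Exchanging 1-amino-2-methylpropyl for 3-amino-3-carboxypropyl on the same carbonyl carbon gives a 1.5-fold lower number from compound 2 to compound 3 (0.17 log units; within the scatter), so this change separates nothing within the scatter. No supporting data bear on the reason for either step.

Going by these compounds, whether a still longer chain continues the trend remains open. So does the effect of an amide replacing the carboxylic acid, or of removing the amine.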